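Methoxy to amino on the six-membered core: cytotoxicity notes

The source may hold more compounds than are shown below. What is called first, only, known or untested is meant among the compounds shown, and "the series" means these compounds.

The series shares an anilino-linked six-membered aromatic core carrying a prenyloxy-substituted aniline; the para substituent on that aniline is a nitrile in compound 1 `COc1ncnc(Nc2ccc(C#N)c(OCC=C(C)C)c2)n1` and compound 2 `CC(C)=CCOc1cc(Nc2ncnc(N)n2)ccc1C#N`, and a chlorine in compound 3 `COc1ccnc(Nc2ccc(Cl)c(OCC=C(C)C)c2)n1` and compound 4 `CC(C)=CCOc1cc(Nc2nccc(N)n2)ccc1Cl`. In an ADME assay on MT2 cells (Homo sapiens) for cytotoxicity (a lower number here means that less compound is tolerated, a higher number that more compound is tolerated), compound 1 gives 42000 nM, compound 2 gives 200 nM and compound 3 gives 9000 nM. The difference between the core of compound 1 and the core of compound 3 is not broken down here.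

Among the measured compounds shown here, the one counted step measured so far is amino in place of methoxy on an aromatic carbon, which produced a 210-fold lower number from compound 1 to compound 2 (2.32 log units; beyond the scatter). The change made from compound 3 to compound 4 is amino in place of methoxy on an aromatic carbon. It is the same kind of change, not the same: in the first case the amino enters on a ring with 3 nitrogen, between two ring nitrogen atoms, whereas in the second it enters on a ring with 2 nitrogen, next to the ring nitrogen.

Compound 4 is not yet measured in this assay. For compound 4 the expected step is a 90-fold lower number from compound 3 to compound 4 (1.95 log units; beyond the scatter), somewhat smaller than the measured step because a 210-fold lower number from compound 1 to compound 2 (2.32 log units; beyond the scatter) was seen where the amino entered between two ring nitrogen atoms, whereas in compound 4 it enters next to the ring nitrogen. That expectation rests only on compound 3 at 9000 nM together with that one earlier step. The estimate for compound 4 is therefore 100 nM, expected to fall between 20 nM and 600 nM.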

Compound 4, half-maximal cytotoxic concentration: 500 nM
Estimate against measurement, compound 4: 5.0-fold (0.70 log units) below; low and high end bracket the measured number.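

In this assay, amino in place of methoxy on an aromatic carbon again lowers the number, with an 18-fold lower number from compound 3 to compound 4 (1.26 log units; beyond the scatter), so the direction of the change and a large step are seen on both cores shown, with less compound tolerated in each amino compound. The size of the step does not carry over from one core to the other: the same change on two cores in this assay, a 210-fold lower number (2.32 log units; beyond the scatter) from compound 1 to compound 2 and an 18-fold lower number (1.26 log units; beyond the scatter) from compound 3 to compound 4, 12-fold (1.07 log units) apart, beyond the scatter of two such steps This does not show what sets the size, as the two pairs differ at once in the number of ring nitrogen atoms, in the surroundings of the amino group and in nitrile against chlorine on the aniline, and two steps cannot separate these differences.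

Still open, from the compounds shown here alone, is how much of the gap follows the ring and how much follows the aniline substituent, a question that would need the methoxy and amino pair on one ring with nitrile and with chlorine in turn. Also open, going by these compounds, is whether the lower number stays with other groups in the same place, such as methylamino, dimethylamino or hydroxyl, and whether it holds with a shorter chain in place of the prenyloxy group.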